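This account rests on a few compounds, and the source may have more. Where it says the series, first, only, none or still open, it means among the compounds named here.

Compound 1 `O=C(Nc1ccccc1)Nc1[nH]nc2nnc(-c3ccccc3)c(-c3ccccc3)c12` was tested in a functional assay on PC-3 cells (Homo sapiens) for cytotoxicity; a higher number here means a weaker inhibitor, a lower number a stronger inhibitor. In this assay compound 1 gives > 100000 nM, which is a limit of the assay and not a number. Compound 2 `Nc1nn(Cc2ccccc2)c2nnc(-c3ccccc3)c(-c3ccccc3)c12` also reaches only a limit in this assay, giving > 100000 nM. Compound 3 `Cc1n[nH]c2nnc(N)c-2c1-c1ccccc1` gives 72400 nM in this assay. Compound 1 thus stands at the limit of > 100000 nM in this assay, at which 2 of the 3 values shown sit, with no number of its own. Compound 4 `CCNC(=O)Nc1[nH]nc2nnc(-c3ccccc3)c(-c3ccccc3)c12` has not yet been measured; it differs from compound 1 by ethyl in place of phenyl on an amide-type nitrogen. Going by the values given here, no step between measured compounds is known here, so no step beyond the scatter is expected in this assay from compound 1 to compound 4. The step from compound 1 to compound 4 is estimated as a step that the limit leaves unreadable from compound 1 to compound 4. Compound 4 is expected to give 150000 nM in this assay, between 60000 nM and 400000 nM.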

Compound 4, half-maximal inhibitory concentration: > 100000 nM
Compound 4 was reported as a limit; the forecaster's own chance of this, stated with the estimate: 80%; the middle value does not contradict the limit.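

In this assay compound 4 gives > 100000 nM, a limit of the assay and not a number. Going by these compounds alone, compound 1 also reaches only a limit, and no step between compound 1 and compound 4 can be read. The compounds shown leave open how ethyl and phenyl on the amide-type nitrogen compare.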